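Swapping the ring oxygen for sulfur in compound 1

The source may hold more compounds than are shown below. What is called first, only, known or untested is meant among the compounds shown, and "the series" means these compounds.

Compound 1 `N/C(=N\NC(=S)N1CCOCC1)c1ccccn1` gives 15%
Compound 2 `Cc1ccnc(/C(N)=N/NC(=S)N2CCOCC2)c1` gives 87.4%
Compound 3 `Cc1ccnc(/C(N)=N/NC(=S)N2CCN(c3ccccn3)CC2)c1` gives 79.4%

These three compounds were measured in a functional assay on A-375 cells (Homo sapiens) for cytotoxicity, read by MTT assay, with a stated time of 72 h, tested at 30 uM; on this read-out lower numbers stand for less inhibition of growth and higher numbers for more inhibition of growth at the one concentration tested. Compound 1 stands lowest of the three numbers; compound 3 sits nearer to it and compound 2 furthest, both beyond the scatter. Among the compounds with values here, the one measured step that changes a single place is a number 72.4 percentage points higher from compound 1 to compound 2 (beyond the scatter), a methyl in place of hydrogen on an aromatic carbon. Compound 2 and compound 3 differ in the part attached to the thiocarbonyl carbon, and their two values lie within the scatter of each other.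

Compound 4 `N/C(=N\NC(=S)N1CCSCC1)c1ccccn1` has not yet been measured. It differs from compound 1 by thiomorpholin-4-yl in place of morpholin-4-yl on a thiocarbonyl carbon. Within the data shown here, no measured step touches this place with a comparable change, so nothing here tells how large the step should be. The two values of compound 2 and compound 3 suggest that changing the group on the thiocarbonyl carbon need not move the number much, but that pair differs by more than a single atom. The step from compound 1 to compound 4 is therefore expected to be small, a number 10 percentage points higher from compound 1 to compound 4 (within the scatter), with no firm direction. Compound 4 is estimated at 25%, in a range from 5% to 55% in this assay.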

Compound 4, percent growth inhibition at one concentration: 86%
Compound 4: the middle estimate sits 61 percentage points below what was measured, and the stated range ends below it.
By their numbers in this assay, from the lowest: compound 1; then compounds 3, 4 and 2 (each within the scatter of the next).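

In this assay, the position on the thiocarbonyl carbon turns out to be highly sensitive: thiomorpholin-4-yl in place of morpholin-4-yl gives a number 71 percentage points higher from compound 1 to compound 4 (beyond the scatter). The two groups match in heavy-atom count, ring size, hydrogen-bond donors and acceptors, and charge, so these counts do not separate them and the clear difference in the groups lies in sulfur versus oxygen. The low number for compound 1 is also now seen to be reversed by either of two single changes in different places, the other being a number 72.4 percentage points higher from compound 1 to compound 2 (beyond the scatter), while no data shown here explain why this exchange of one ring atom has so large an effect.

On these data alone, it remains open whether a piperidin-1-yl group, with a ring carbon in place of the oxygen, would read like the thiomorpholin-4-yl group, which would help separate a need for sulfur from a simple dislike of the morpholine oxygen. Also open, as far as these compounds go, is whether the methyl and the thiomorpholin-4-yl group would add up on one core, or whether either change alone already accounts for all the growth inhibition that this read-out can show.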